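This account rests on a few compounds, and the source may have more. Where it says the series, first, only, none or still open, it means among the compounds named here.

Measured in a functional assay on KB cells (Homo sapiens) for inhibition; a lower number here means a stronger inhibitor, a higher number a weaker inhibitor:
Compound 1 `Nc1nc2cc(Cl)c(Cl)cc2n1Cc1cccc([N+](=O)[O-])c1`: 65000 nM
Compound 2 `O=[N+]([O-])c1cccc(Cn2c(Cl)nc3cc(Cl)c(Cl)cc32)c1`: 239000 nM
Compound 3 `Clc1cccc(Cn2c(Br)nc3cc(Cl)c(Cl)cc32)c1`: > 100000 nM (a limit)

Compound 3 is known only through a limit of the assay, > 100000 nM, and not as a number. Compound 4 `O=[N+]([O-])c1cccc(Cn2c(Br)nc3cc(Cl)c(Cl)cc32)c1` differs from it by one change, (nitro in place of chloro on an aromatic carbon), nitro in place of chloro on an aromatic carbon, meta to a large group. Among the compounds with values here, the one measured step, a 3.7-fold higher number from compound 1 to compound 2 (0.57 log units; beyond the scatter), is chloro in place of amino and does not test this change. Closer guidance comes from compound 2, which also bears nitro and gives 239000 nM. In this assay, within the data shown here, no large step is therefore expected. The expected step is a step that the limit leaves unreadable from compound 3 to compound 4. Compound 4 is estimated at 180000 nM, with an expected range of 70000 nM to 450000 nM.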

Compound 4, half-maximal inhibitory concentration: 150000 nM
For compound 4 the middle estimate is 1.2-fold (0.08 log units) above the measured one; low and high end bracket the measured number.
By their numbers in this assay, from the lowest: compound 1; then compounds 4 and 2 (each within the scatter of the next).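

Putting bromo where chloro stood gives a 1.6-fold lower number from compound 2 to compound 4 (0.20 log units; within the scatter), so in this assay these two halogens are not told apart at this position. Bromo in place of amino gives a 2.3-fold higher number from compound 1 to compound 4 (0.36 log units; beyond the scatter), in the same direction as chloro in place of amino, a 3.7-fold higher number from compound 1 to compound 2 (0.57 log units; beyond the scatter). The step of nitro in place of chloro cannot be read because compound 3 is known only as a limit: the limit of > 100000 nM in this assay, at which 1 of the 4 values shown sits.

Going by these compounds, what a methyl or methoxy group would give at the carbon that carries bromo remains open, as does the effect of a nitrile in place of nitro.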